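From Substituted Phenyl Amides to a Thiophene Amide

A few compounds are considered here, and "the series" means these few. Any claim that something is new, unique, unknown or untested is made for them only; others in the source may bear on it.

Three compounds sharing one core have been measured in an assay for binding affinity to 5-hydroxytryptamine receptor 1B (Homo sapiens), read by radioligand binding; on this read-out higher numbers stand for weaker inhibition and lower numbers for stronger inhibition:

Compound 1, `CN1CCC(c2c[nH]c3ccc(NC(=O)c4cccc(F)c4)nc23)CC1`: 1600 nM
Compound 2, `CN1CCC(c2c[nH]c3ccc(NC(=O)c4ccc(C#N)cc4)nc23)CC1`: 310 nM
Compound 3, `CN1CCC(c2c[nH]c3ccc(NC(=O)c4ccc([N+](=O)[O-])cc4)nc23)CC1`: 270 nM

Compound 3 gives the lowest of the three numbers in this assay. Its nearest neighbour is compound 2, and the step of a 1.1-fold lower number from compound 2 to compound 3 (0.06 log units; within the scatter) lies within the scatter, so the two cannot be ordered. Compound 1 is the furthest away, as shown by a 5.9-fold lower number from compound 1 to compound 3 (0.77 log units; beyond the scatter).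

Compound 4, `CN1CCC(c2c[nH]c3ccc(NC(=O)c4cccs4)nc23)CC1`, is the compound not yet measured. It differs from compound 3 in one place: thiophen-2-yl in place of 4-nitrophenyl on a carbonyl carbon.

Two of the measured steps bear on this change, though only at a distance. Both a 5.2-fold lower number from compound 1 to compound 2 (0.71 log units; beyond the scatter) and a 5.9-fold lower number from compound 1 to compound 3 (0.77 log units; beyond the scatter) show that a six-membered aromatic ring carrying a substituent on the carbonyl carbon gives a lower number than 3-fluorophenyl, while a 1.1-fold lower number from compound 2 to compound 3 (0.06 log units; within the scatter) shows that exchanging nitro for cyano changes nothing beyond the scatter. Going by the values given here, no measured step exchanges the six-membered ring itself for a five-membered ring, so the effect of thiophen-2-yl is untested here.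

Taking the loss of the substituted phenyl as the main point, compound 4 is expected to give a higher number, a step estimated at a 3.0-fold higher number from compound 3 to compound 4 (0.47 log units; beyond the scatter). Compound 4 is therefore estimated at 800 nM, within a range from 250 nM to 2500 nM.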

Compound 4, inhibition constant: 390 nM
Compound 4: middle estimate off by 2.1-fold (0.31 log units), on the high side; low and high end bracket the measured number.
By their numbers in this assay, from the lowest: compounds 3, 2 and 4 (each within the scatter of the next); then compound 1.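

The carbonyl carbon of the amide accepts a five-membered aromatic ring with one hetero atom in place of a substituted six-membered ring: in this assay, neither the exchange for 4-nitrophenyl (a 1.4-fold higher number from compound 3 to compound 4 (0.16 log units; within the scatter)) nor that for 4-cyanophenyl (a 1.3-fold higher number from compound 2 to compound 4 (0.10 log units; within the scatter)) goes beyond the scatter. Compounds 2, 3 and 4 therefore cannot be ordered, and neither the nitro nor the cyano group is needed on this carbonyl carbon to reach their range of numbers. Thiophen-2-yl also separates from 3-fluorophenyl (a 4.1-fold lower number from compound 1 to compound 4 (0.61 log units; beyond the scatter)), so among these four compounds, compound 1 alone stands apart, and the earlier link between a substituted six-membered ring and a lower number does not extend to a requirement for such a ring.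

The compounds shown offer nothing that would account for these steps.

Plain phenyl on the same carbonyl carbon would show whether the 3-fluorophenyl of compound 1 is unusual for its fluorine or for where that fluorine sits. Thiophen-3-yl and furan-2-yl would show whether the attachment point of the five-membered ring and its sulfur matter at all.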